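A few compounds are considered here, and "the series" means these few. Any claim that something is new, unique, unknown or untested is made for them only; others in the source may bear on it.

Compound 1 `O=C(Nc1ccc(Cl)cc1)Nc1ccc(C(=O)NO)cc1` gives 870 nM
Compound 2 `COc1ccc(NC(=O)Nc2ccc(/C=C/C(=O)NO)cc2)cc1` gives 460 nM
Compound 3 `O=C(/C=C/c1ccc(NC(=O)Nc2ccc([N+](=O)[O-])cc2)cc1)NO` gives 580 nM

These three values come from a functional assay on NAMALVA cells (Homo sapiens) for cytotoxicity, read by MTT assay, with a stated time of 72 h (on this read-out lower numbers stand for stronger inhibition and higher numbers for weaker inhibition), and form a tight group. Compound 2 at 460 nM stands within the scatter of both compound 3 and compound 1, so it is not separated from either.

The step under consideration leads to compound 4 `COc1ccc(NC(=O)Nc2ccc(CCC(=O)NO)cc2)cc1` through the change 2-(hydroxycarbamoyl)ethyl in place of 2-(hydroxycarbamoyl)ethenyl on an aromatic carbon on the same shared core. For the measured compounds named here, the only measured single-place step is a 1.3-fold higher number from compound 2 to compound 3 (0.10 log units; within the scatter) and it leaves the 2-(hydroxycarbamoyl)ethenyl group untouched, so it gives no direct reading on this change. Compound 1 at 870 nM lacks this chain altogether and also differs from compound 2 in a second place, so it cannot isolate the chain either. Going by the values given here, no measured compound carries the 2-(hydroxycarbamoyl)ethyl group, and even the direction is therefore poorly supported. A small move toward a higher number is tentatively expected, with a wide range around it. The estimated step is a 1.7-fold higher number from compound 2 to compound 4 (0.24 log units; within the scatter) in this assay on this reading. Compound 4 is expected at 800 nM with an estimated range from 300 nM to 2200 nM in the coming measurement.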

Compound 4, half-maximal inhibitory concentration: 1990 nM
For compound 4 the middle estimate is 2.5-fold (0.40 log units) below the measured one; measured number inside the range.
By their numbers in this assay, from the lowest: compounds 2, 3 and 1 (each within the scatter of the next); then compound 4.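

In this assay, 2-(hydroxycarbamoyl)ethyl in place of 2-(hydroxycarbamoyl)ethenyl, on the aromatic carbon para to a large group, gives a 4.3-fold higher number from compound 2 to compound 4 (0.64 log units; beyond the scatter). For the compounds shown here, this is the first single-place step to lie beyond the scatter, whereas nitro in place of methoxy gave a 1.3-fold higher number from compound 2 to compound 3 (0.10 log units; within the scatter), so this position registers a change that the earlier pair could not resolve. The two chains match in heavy atoms, hydrogen-bond donors and hydrogen-bond acceptors and differ only in their double bonds outside aromatic rings, which ties the higher number to the loss of the chain's carbon-carbon double bond on this methoxy-bearing pair, although no measurement available here explains the shift.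

Going by these compounds, whether the same step appears with the nitro group of compound 3 in place of the methoxy group remains open. Also open, on these data alone, is how a longer chain ending in the hydroxycarbamoyl group, or a carboxylic acid in place of that group, would read at this position in this assay.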